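A few compounds are considered here, and "the series" means these few. Any claim that something is new, unique, unknown or untested is made for them only; others in the source may bear on it.

Measured in a functional assay on KB cells (Homo sapiens) for antiproliferative activity, read by MTT assay, with a stated time of 48 h; on this read-out higher numbers stand for weaker inhibition and lower numbers for stronger inhibition:
compound 1 `Cc1c(Cc2ccccc2)c(=O)oc2cc(OCCOc3no[n+]([O-])c3S(=O)(=O)c3ccccc3)ccc12`: 4540 nM
compound 2 `COc1cc(OCCOc2no[n+]([O-])c2S(=O)(=O)c2ccccc2)ccc1C(=O)/C=C/c1ccc(F)cc1`: 1670 nM
compound 3 `COCCOc1no[n+]([O-])c1S(=O)(=O)c1ccccc1`: 3690 nM

Compound 1 (at 4540 nM) lies within the scatter of compound 3, so these two cannot be told apart in this assay. Compound 2 gives a lower number than compound 1, a gap beyond the scatter that stands for stronger inhibition.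

The next compound, compound 4 `CNS(=O)(=O)Nc1cccc(Cc2c(C)c3ccc(OCCOc4no[n+]([O-])c4S(=O)(=O)c4ccccc4)cc3oc2=O)c1`, keeps the core of compound 1 and changes only its phenyl group, which becomes 3-((methylsulfamoyl)amino)phenyl. The change is (methylsulfamoyl)amino in place of hydrogen on an aromatic carbon and places (methylsulfamoyl)amino in place of hydrogen on an aromatic carbon, meta to a large group.

Among the measured compounds shown here, no pair of measured compounds shows what this change does, so any expectation rests on the overall spread. The three compounds differ widely in structure, yet they run only from compound 2 at 1670 nM to compound 1 at 4540 nM, and compound 3 stays at 3690 nM with far less attached. In this assay, no step beyond the scatter is therefore expected. The estimated step of a 1.3-fold lower number from compound 1 to compound 4 (0.11 log units; within the scatter) is expected to be small, towards a slightly lower number. For compound 4 the expected value is 3500 nM, with an estimated range from 1200 nM to 10000 nM.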

Compound 4, half-maximal inhibitory concentration: 1140 nM
Beside the measured number, compound 4's estimate is 3.1-fold (0.49 log units) above it, outside the stated range (below it).
By their numbers in this assay, from the lowest: compounds 4 and 2 (each within the scatter of the next); then compounds 3 and 1 (each within the scatter of the next).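

In this assay, among the compounds shown here, the one pair that differs in a single place gives a 4.0-fold lower number from compound 1 to compound 4 (0.60 log units; beyond the scatter), a step beyond the scatter that stands for stronger inhibition. This shows that the phenyl group of compound 1 is not indifferent to substitution: (methylsulfamoyl)amino in place of hydrogen on an aromatic carbon, meta to a large group, moves the number by more than repeated measurements would. The earlier compounds shown here differ from one another in many places and offered only an overall spread, whereas this step ties a change in the number to one substituent at one position. Nothing at hand accounts for the size or direction of this step.

The compounds shown leave open whether the step belongs to the whole (methylsulfamoyl)amino group or to only a part of it, as neither a simple amine nor a methanesulfonylamino group appears at this position among them. They also leave open whether (methylsulfamoyl)amino would give a similar step at another position on the phenyl group, or whether a carboxylic acid at the same position would move the number in the same direction.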